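The compounds below may be only part of what the source reports. "The series", "measured", "known", "first", "only" and "open" are said of these compounds alone.

Measured so far in a functional assay on OVCAR-3 cells (Homo sapiens); a higher number here means a weaker inhibitor of growth, a lower number a stronger inhibitor of growth: compound 1 `COc1cc(CSc2cc(Cl)c(-c3nnc(-c4ccccc4)s3)cc2S(=O)(=O)NC(=N)NO)cc(OC)c1OC` gives 2190 nM; compound 2 `COc1cc(CSc2cc(Cl)c(-c3nc(-c4ccc(Cl)cc4)no3)cc2S(=O)(=O)NC(=N)NO)cc(OC)c1OC` gives 1910 nM; compound 3 `N=C(NO)NS(=O)(=O)c1cc(-c2nc(-c3ccccc3)no2)c(Cl)cc1SCc1ccccc1` gives 1690 nM.

For the measured compounds named here, compound 2 stands between the other two numbers, and both gaps lie within the scatter; the single one-point step, a 1.1-fold lower number from compound 1 to compound 2 (0.06 log units; within the scatter), is likewise within the scatter. Compound 4 `COc1cc(CSc2cc(Cl)c(-c3nnc(-c4ccc(Cl)cc4)s3)cc2S(=O)(=O)NC(=N)NO)cc(OC)c1OC` differs from compound 2 by 5-(4-chlorophenyl)-1,3,4-thiadiazol-2-yl in place of 3-(4-chlorophenyl)-1,2,4-oxadiazol-5-yl on an aromatic carbon. Going by the values given here, the only step that bears on this is the one from compound 1 to compound 2, which exchanged the five-membered aromatic ring and brought in the chloro group together with no change beyond the scatter; compound 4 reverses only the ring exchange. No step beyond the scatter is therefore expected in this assay. Compound 4 is expected at 2000 nM, within 1000 nM to 4000 nM. The expected step is a 1.0-fold higher number from compound 2 to compound 4 (0.02 log units; within the scatter).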

Compound 4, concentration for 50% growth inhibition: 10200 nM
Beside the measured number, compound 4's estimate is 5.1-fold (0.71 log units) below it, and the stated range ends below it.
By their numbers in this assay, from the lowest: compounds 3, 2 and 1 (each within the scatter of the next); then compound 4.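

Exchanging 3-(4-chlorophenyl)-1,2,4-oxadiazol-5-yl for 5-(4-chlorophenyl)-1,3,4-thiadiazol-2-yl gives a 5.3-fold higher number from compound 2 to compound 4 (0.73 log units; beyond the scatter) in this assay, so with the chloro group present, this position responds to the ring change. With the thiadiazole kept, chloro in place of hydrogen gives a 4.7-fold higher number from compound 1 to compound 4 (0.67 log units; beyond the scatter). The earlier step, a 1.1-fold lower number from compound 1 to compound 2 (0.06 log units; within the scatter), therefore combined two changes that offset each other.

No supporting data explain either step. Open questions are how chloro acts on the oxadiazole series and whether an amine or carboxylic acid in its place on the phenyl ring is tolerated.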